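The compounds below may be only part of what the source reports. "The series", "measured", "known", "first", "only" and "open" are said of these compounds alone.

Measured so far in a functional assay on cells (Homo sapiens) for inhibition, read by MTT assay, with a stated time of 48 h; a higher number here means a weaker inhibitor, a lower number a stronger inhibitor:
compound 1 `O=C(CCCCOc1no[n+]([O-])c1S(=O)(=O)c1ccccc1)NO`, 4300 nM
compound 2 `O=C(CCCCCCOc1no[n+]([O-])c1S(=O)(=O)c1ccccc1)NO`, "not determined" (no result reported)
compound 3 `O=C(CCCCCCCOc1no[n+]([O-])c1S(=O)(=O)c1ccccc1)NO`, "not determined" (no result reported)

Within the data shown here, compound 1 holds the only number in this assay; compound 1 gives 4300 nM. Among the measured compounds shown here, compounds 2 and 3 carry longer saturated chains to the hydroxycarbamoyl end, but neither has a reported value, so no step between measured compounds exists in this assay.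

Compound 4 `O=C(/C=C/COc1no[n+]([O-])c1S(=O)(=O)c1ccccc1)NO` differs from compound 1 as 2-(hydroxycarbamoyl)ethenyl in place of 3-(hydroxycarbamoyl)propyl on a saturated chain carbon bound to an oxygen on an aromatic ring. The hydroxycarbamoyl end and the shared core stay; the connecting chain is shortened by one carbon and gains a double bond outside aromatic rings.

For the measured compounds named here, with no measured step to lean on, the expected step from compound 1 to compound 4 is modest and of uncertain direction, likely not beyond the scatter: a 1.2-fold lower number from compound 1 to compound 4 (0.09 log units; within the scatter). Compound 4 is therefore estimated at 3500 nM, within 900 nM to 14000 nM.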

Compound 4, half-maximal inhibitory concentration: 57700 nM
Beside the measured number, compound 4's estimate is 16-fold (1.22 log units) below it; the measured number lies above the stated range.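

In this assay, this position proves sensitive to the connecting chain: 2-(hydroxycarbamoyl)ethenyl in place of 3-(hydroxycarbamoyl)propyl gives a 13-fold higher number from compound 1 to compound 4 (1.13 log units; beyond the scatter) with the hydroxycarbamoyl end and shared core kept. This single step combines a shorter chain with an added double bond outside aromatic rings, and the two changes cannot be separated here. No evidence on the cause is available.

Steps to compounds 2 and 3 cannot be read, so the effect of a longer saturated chain remains unknown. Also open, going by these compounds, are a saturated 3-(hydroxycarbamoyl)propan-1-yl chain and a carboxylic acid replacing the hydroxycarbamoyl end.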